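Working notes: from compound 2 to compound 3

This account rests on a few compounds, and the source may have more. Where it says the series, first, only, none or still open, it means among the compounds named here.

- compound 1 `CC1(C)CCc2cc(C(=O)/C=C/c3ccc(OCc4cn(-c5ccc(Br)cc5)nn4)cc3)c(O)cc2O1`: "not active" (no number reported)
- compound 2 `Cc1c(-n2cc(COc3ccc(/C=C/C(=O)c4cc5c(cc4O)OC(C)(C)CC5)cc3)nn2)cccc1[N+](=O)[O-]`: 176000 nM

For the measured compounds named here, in a functional assay on MCF7 cells (Homo sapiens) for antiproliferative activity, read by MTT assay (a higher number here means a weaker inhibitor, a lower number a stronger inhibitor), compound 2 gives 176000 nM, the only number so far. Compound 1 gives "not active" (no number reported), so no comparison can be made between the two. Compound 3 `CC(=O)c1ccc(-n2cc(COc3ccc(/C=C/C(=O)c4cc5c(cc4O)OC(C)(C)CC5)cc3)nn2)cc1` differs from compound 2 by 4-acetylphenyl in place of 2-methyl-3-nitrophenyl on an aromatic nitrogen, with 4-acetylphenyl in place of 2-methyl-3-nitrophenyl on an aromatic nitrogen. No measured step sizes this change, so only a modest move towards stronger inhibition in this assay is expected, possibly none beyond the scatter. The expected change is a 1.8-fold lower number from compound 2 to compound 3 (0.25 log units; within the scatter). Compound 3 is estimated at 100000 nM, with an expected range of 25000 nM to 300000 nM.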

Compound 3, half-maximal inhibitory concentration: 182000 nM
For compound 3 the middle estimate is 1.8-fold (0.26 log units) below the measured one, within the range that was stated.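

In this assay, for the compounds shown here, the change to 4-acetylphenyl in place of 2-methyl-3-nitrophenyl on an aromatic nitrogen gives a 1.0-fold higher number from compound 2 to compound 3 (0.01 log units; within the scatter) and so provides the first measured step at this position. These two substituted phenyl groups read alike here, and the step leaves the series in the same weak range. No evidence on hand bears on this result.

As far as these compounds go, whether a carboxylic acid or an amine on this phenyl ring would move the number beyond the scatter remains open. So does the effect of any change to the shared core.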